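The source may report more compounds than this note shows. Statements on the series, on what has been measured and on what is new or still open speak of the compounds shown alone.

Measured so far in an assay for inhibition of kynurenine 3-monooxygenase (Rattus norvegicus); on this read-out higher numbers stand for weaker inhibition and lower numbers for stronger inhibition:
compound 1, `COC(=O)C(=O)/C=C(\O)c1cccc(Cl)c1`, gives 1900 nM;
compound 2, `COC(=O)C(=O)/C=C(\O)c1cccc(Br)c1`, gives 2100 nM.

Compound 2 stands highest of these two numbers, but only just: its nearest neighbour is compound 1, and the step of a 1.1-fold higher number from compound 1 to compound 2 (0.04 log units; within the scatter) lies within the scatter, so the two are not told apart. Compound 3, `COC(=O)C(=O)/C=C(\O)c1cccc(F)c1`, differs from compound 2 by fluoro in place of bromo on an aromatic carbon. Within the data shown here, the only measured step that bears on this change is the earlier halogen exchange at the same carbon, a 1.1-fold higher number from compound 1 to compound 2 (0.04 log units; within the scatter), which did nothing beyond the scatter. On that basis no step beyond the scatter is expected in this assay for compound 3, in either direction. Compound 3 is therefore estimated at 2000 nM, with a range from 900 nM to 4500 nM. This estimate means a step of a 1.1-fold lower number from compound 2 to compound 3 (0.02 log units; within the scatter), expected to fall within the scatter.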

Compound 3, half-maximal inhibitory concentration: 1600 nM
For compound 3 the middle estimate is 1.3-fold (0.10 log units) above the measured one, within the range that was stated.
By their numbers in this assay, from the lowest: compounds 3, 1 and 2 (each within the scatter of the next).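

In this assay, fluoro at this aromatic carbon, meta to a group of 9 heavy atoms, gives a 1.3-fold lower number from compound 2 to compound 3 (0.12 log units; within the scatter) against bromo and a 1.2-fold lower number from compound 1 to compound 3 (0.07 log units; within the scatter) against chloro. With the smallest of the three halogens now included, fluoro, chloro and bromo all lie within the scatter of one another, so this read-out does not tell them apart at this place. Nothing at hand offers an explanation for this result.

From the compounds shown here alone, all three compounds carry a halogen at this one carbon, so it stays open whether a bare hydrogen, a methoxy group or an amine there would give a different number. Also open, going by these compounds, is what a carboxylic acid in place of the methyl ester would do to the core shared by these compounds.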